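The source may report more compounds than this note shows. Statements on the series, on what has been measured and on what is new or still open speak of the compounds shown alone.

The two measured compounds share one core: compound 1 `NS(=O)(=O)NCCC1CCN(c2cc(-c3ccccc3)ncn2)CC1` carries an unsubstituted phenyl group, while compound 2 `NS(=O)(=O)NCCC1CCN(c2cc(-c3ccc(Cl)cc3)ncn2)CC1` carries a chlorine on that phenyl ring. In a functional assay on HT-29 cells (Homo sapiens) for antiproliferative activity, read by sulforhodamine B assay, with a stated time of 48 h (a higher number here means a weaker inhibitor of growth, a lower number a stronger inhibitor of growth), compound 1 gives 66500 nM, and in this assay compound 2 gives 30500 nM. For the measured compounds named here, the only measured step is a 2.2-fold lower number from compound 1 to compound 2 (0.34 log units; beyond the scatter), and on these two numbers compound 2 stands with the lowest value, its nearest neighbour being compound 1.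

Compound 3 `NS(=O)(=O)NCCC1CCN(c2cc(-c3ccccc3Cl)ncn2)CC1` keeps the chlorine but moves it on the phenyl ring: 2-chlorophenyl in place of 4-chlorophenyl on an aromatic carbon. Going by the values given here, no measured step compares the two positions of the chlorine with each other. The step of a 2.2-fold lower number from compound 1 to compound 2 (0.34 log units; beyond the scatter) shows only that adding a chlorine to make the 4-chlorophenyl group lowered the number modestly; it gives no guide to what placing it in the 2-chlorophenyl arrangement does, and in either direction the data are silent. The expectation for compound 3 is therefore a step of a 1.5-fold higher number from compound 2 to compound 3 (0.17 log units; within the scatter) that stays within the scatter or only slightly beyond it. In this assay compound 3 is estimated at 45000 nM, with a range from 15000 nM to 130000 nM.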

Compound 3, concentration for 50% growth inhibition: 52900 nM
Beside the measured number, compound 3's estimate is 1.2-fold (0.07 log units) below it; the measured number falls inside the stated range.
By their numbers in this assay, from the lowest: compounds 2, 3 and 1 (each within the scatter of the next, the first and the last beyond it).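

Moving the chlorine to give the 2-chlorophenyl group produces a 1.7-fold higher number from compound 2 to compound 3 (0.24 log units; within the scatter) in this assay, so this assay does not separate the 2-chlorophenyl and 4-chlorophenyl groups. For the compounds shown here, the comparison with the unsubstituted phenyl ring adds a second point: the 2-chlorophenyl group gives a 1.3-fold lower number from compound 1 to compound 3 (0.10 log units; within the scatter), whereas the 4-chlorophenyl group gave a 2.2-fold lower number from compound 1 to compound 2 (0.34 log units; beyond the scatter), and only that second change lies beyond the scatter. Compound 3 therefore sits within the scatter of both neighbours, and the data show a clear gain from adding chlorine only for the 4-chlorophenyl group, while no accompanying measurement bears on what lies behind these numbers.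

The compounds shown carry only hydrogen or chlorine on this phenyl ring, so they leave open what a fluorine, a methoxy group, a nitrile, an amine or a carboxylic acid would do there. They also leave open how a 3-chlorophenyl group would compare, and whether two chlorines on the same ring would bring a larger step than one.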